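Swapping the amide aryl group on a flavonol scaffold

This account rests on a few compounds, and the source may have more. Where it says the series, first, only, none or still open, it means among the compounds named here.

Compound 2 `COc1ccc(C(=O)Nc2cccc(-c3oc4cc(-c5ccc(F)cc5)ccc4c(=O)c3O)c2)c(F)c1` and compound 1 `O=C(Nc1cccc(-c2oc3cc(-c4ccc(F)cc4)ccc3c(=O)c2O)c1)c1ccc(C(F)(F)F)cc1` share a core and differ only in the aryl group attached to the amide carbonyl carbon. In a functional assay on A549 cells (Homo sapiens) for antiproliferative activity, read by CCK-8 assay, with a stated time of 72 h (on this read-out higher numbers stand for weaker inhibition and lower numbers for stronger inhibition), compound 1 gives 19400 nM, while compound 2 gives 40000 nM, the higher of the two numbers; the change was a 2.1-fold higher number from compound 1 to compound 2 (0.31 log units; beyond the scatter). Compound 3 `CCCc1ccc(C(=O)Nc2cccc(-c3oc4cc(-c5ccc(F)cc5)ccc4c(=O)c3O)c2)cc1` is the next member, and its difference from compound 2 is 4-propylphenyl in place of 2-fluoro-4-methoxyphenyl on a carbonyl carbon. For the measured compounds named here, only one measured step is available, and it concerns a different aryl group, so it offers a weak guide: it shows that replacing the aryl group on this carbonyl carbon moved the number modestly. A change of similar modest size is expected here, more likely downward toward compound 1 than upward. Compound 3 is therefore estimated at 22000 nM, with a range from 8000 nM to 60000 nM, corresponding to an expected step of a 1.8-fold lower number from compound 2 to compound 3 (0.26 log units; within the scatter).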

Compound 3, half-maximal inhibitory concentration: 47600 nM
Estimate against measurement, compound 3: 2.2-fold (0.34 log units) below; the range from low to high includes it.
By their numbers in this assay, from the lowest: compound 1; then compounds 2 and 3 (each within the scatter of the next).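

In this assay, 4-propylphenyl in place of 2-fluoro-4-methoxyphenyl on the carbonyl carbon gives a 1.2-fold higher number from compound 2 to compound 3 (0.08 log units; within the scatter), so this position does not separate an all-carbon group from one holding oxygen and fluorine. Propyl in place of trifluoromethyl on an aromatic carbon gives a 2.5-fold higher number from compound 1 to compound 3 (0.39 log units; beyond the scatter), a modest step that leaves compound 1 with the lowest number of the three. Nothing available here explains these numbers.

On these data alone, all three compounds carry a substituted phenyl group at this position, so it remains open whether an amine, a carboxylic acid or a chain longer than propyl on that ring would move the number further. As far as these compounds go, it is also open whether any group here can go well below compound 1 at 19400 nM.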